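A Branched Secondary Amine Replaces Diethylamino

This account rests on a few compounds, and the source may have more. Where it says the series, first, only, none or still open, it means among the compounds named here.

Three compounds share one core and were tested in an assay on cell membranes for displacement of a labelled ligand from corticotropin-releasing factor receptor 1 (Rattus norvegicus); on this read-out higher numbers stand for weaker inhibition and lower numbers for stronger inhibition. Compound 1 `CCCN(CC1CC1)c1nc(C)nc2c(-c3ccc(OC)cc3C)c(C)nn12` gives 1.96 nM, compound 2 `CCN(CC)c1nc(C)nc2c(-c3c(C)cc(OC)cc3OC)c(C)nn12` gives 1.2 nM, and compound 3 `CCN(CC)c1nc(C)nc2c(-c3cc(F)c(OC)cc3Cl)c(C)nn12` gives 1.64 nM. Compound 2 has the lowest of these three numbers, yet its gaps to compound 3 and to compound 1 both fall within the usual scatter, so the three are indistinguishable on this read-out.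

Compound 4 `CCCC(C)Nc1nc(C)nc2c(-c3c(C)cc(OC)cc3OC)c(C)nn12` has not yet been measured. It differs from compound 2 in one place: (1-methylbutyl)amino in place of diethylamino on an aromatic carbon. Among the compounds with values here, no measured pair shows this kind of change, so its effect is unknown. A modest step from compound 2 to compound 4 is expected, a 2.9-fold higher number from compound 2 to compound 4 (0.46 log units; beyond the scatter), likely toward a weaker number, because compound 2 already gives 1.2 nM. Compound 4 is estimated at 3.5 nM, within 1 nM to 12 nM.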

Compound 4, half-maximal inhibitory concentration: 2.14 nM
Compound 4: middle estimate off by 1.6-fold (0.21 log units), on the high side, within the range that was stated.
By their numbers in this assay, from the lowest: compounds 2, 3, 1 and 4 (each within the scatter of the next).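

In this assay, (1-methylbutyl)amino in place of diethylamino on this aromatic carbon gives a 1.8-fold higher number from compound 2 to compound 4 (0.25 log units; within the scatter), so the two groups cannot be told apart on this read-out. This position therefore accepts a group with one hydrogen-bond donor in place of one with none, and 6 heavy atoms in place of 5, without a change beyond the scatter. Nothing measured here explains why the two groups read alike.

Still open, on these data alone, is how a morpholine ring or a longer chain on the amine nitrogen would read at this position. Also open, as far as these compounds go, is whether (1-methylbutyl)amino reads the same alongside the other aryl groups on the shared core.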